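The source may report more compounds than this note shows. Statements on the series, on what has been measured and on what is new or still open speak of the compounds shown alone.

Compound 1 `O=C1Cc2c(csc2-c2ccccc2)C2(CCN(Cc3ccccc3)CC2)O1`: 2.5 nM
Compound 2 `COc1ccc(-c2scc3c2CC(=O)OC32CCN(Cc3ccccc3)CC2)cc1`: 11 nM

Both compounds were tested in an assay on membranes from brain for displacement of a labelled ligand from Sigma non-opioid intracellular receptor 1 (Cavia porcellus), read by scintillation counting, with a stated time of 120 min; a lower number here means a stronger inhibitor, a higher number a weaker inhibitor. Going by the values given here, compound 2 has the higher of the two numbers; its only neighbour is compound 1, and the gap between them is a 4.4-fold higher number from compound 1 to compound 2 (0.64 log units; beyond the scatter), which is beyond the usual scatter. Compound 3 `O=C1Cc2c(csc2-c2ccc(-c3ccccc3)cc2)C2(CCN(Cc3ccccc3)CC2)O1` has not yet been measured in this assay. It differs from compound 2 by phenyl in place of methoxy on an aromatic carbon. Among the compounds with values here, only one measured step touches the same aromatic carbon: the one in which a methoxy group replaced hydrogen there, giving a 4.4-fold higher number from compound 1 to compound 2 (0.64 log units; beyond the scatter). That step shows that putting a group on this carbon made the compound a modestly weaker inhibitor, but it says nothing directly about a phenyl group in the same place, which is a different substitution. Within the data shown here, with no closer precedent, the step in this assay is expected to be small, leaning slightly towards a higher number, a 1.4-fold higher number from compound 2 to compound 3 (0.13 log units; within the scatter). The inhibition constant of compound 3 is therefore estimated at 15 nM, within a range from 4 nM to 60 nM.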

Compound 3, inhibition constant: 108 nM
Compound 3: middle estimate off by 7.2-fold (0.86 log units), on the low side; measured number outside the range, above it.
By their numbers in this assay, from the lowest: compound 1; then compound 2; then compound 3.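

At the aromatic carbon para to a large group, the outcome in this assay clearly depends on which group is attached: replacing methoxy with phenyl gives a 9.8-fold higher number from compound 2 to compound 3 (0.99 log units; beyond the scatter) as a further loss, so the modest change seen earlier with methoxy does not describe every substituent at this carbon. Against hydrogen, phenyl gives a 43-fold higher number from compound 1 to compound 3 (1.64 log units; beyond the scatter) as a large step, whereas methoxy gave a 4.4-fold higher number from compound 1 to compound 2 (0.64 log units; beyond the scatter) as a modest one; both groups make the compound a weaker inhibitor, and phenyl, with its greater heavy-atom count and its ring, does so to the greater extent. No available measurement bears on the reason for this difference.

Three compounds cannot show whether the trend follows the number of heavy atoms or the presence of an aromatic ring, and a cyclohexyl ring or a butyl chain at this carbon would help separate the two. As far as these compounds go, it also remains open whether a fluorine atom, an amine or a carboxylic acid here would keep the number close to that of compound 1 or raise it further.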